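The source may hold more compounds than are shown below. What is called first, only, known or untested is meant among the compounds shown, and "the series" means these compounds.

Compound 1, `CCCCCCCCc1ccc(OCC(=O)Cn2nnc(C)n2)cc1`, in an assay on microsomes from brain for inhibition of Fatty-acid amide hydrolase 1 (Rattus norvegicus), read by fluorescence and HPLC, with a stated time of 60 min (on this read-out lower numbers stand for stronger inhibition and higher numbers for weaker inhibition), gives 27 nM.
Compound 2, `CCCCCCCCc1ccc(OCC(=O)Cn2nnc(-c3ccccc3)n2)cc1`, gives 24 nM.
Compound 3, `CCCCCCCCc1ccc(OCC(=O)Cn2nnc(-c3cccnc3)n2)cc1`, gives 23 nM.

Compound 3 carries the lowest of the three numbers, but its standing is only nominal: the two steps that lead to it, a 1.0-fold lower number from compound 2 to compound 3 (0.02 log units; within the scatter) and a 1.2-fold lower number from compound 1 to compound 3 (0.07 log units; within the scatter), both lie within the scatter of this assay. Compound 4, `CCCCCCCCc1ccc(OCC(=O)Cn2nnc(-c3ccccn3)n2)cc1`, differs from compound 3 by a single change: pyridin-2-yl in place of pyridin-3-yl on an aromatic carbon.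

Within the data shown here, three measured steps bear on the question of what the group at this position does. From compound 1 to compound 2 the number moved by a 1.1-fold lower number from compound 1 to compound 2 (0.05 log units; within the scatter), from compound 1 to compound 3 by a 1.2-fold lower number from compound 1 to compound 3 (0.07 log units; within the scatter), and from compound 2 to compound 3 by a 1.0-fold lower number from compound 2 to compound 3 (0.02 log units; within the scatter). Methyl, phenyl and pyridin-3-yl at this carbon therefore give numbers that cannot be told apart. Moving the ring nitrogen to make pyridin-2-yl is a smaller change than any of those, so no step beyond the scatter is expected in either direction. Compound 4 is thus estimated at 23 nM, with a range from 12 nM to 46 nM, which means an expected step of no change at the digits printed from compound 3 to compound 4 (within the scatter).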

Compound 4, half-maximal inhibitory concentration: 18 nM
Beside the measured number, compound 4's estimate is 1.3-fold (0.11 log units) above it; low and high end bracket the measured number.
By their numbers in this assay, from the lowest: compounds 4, 3, 2 and 1 (each within the scatter of the next).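

In this assay, pyridin-2-yl becomes the fourth group on this aromatic carbon, between two ring nitrogen atoms, that cannot be told apart from the others: the exchange for pyridin-3-yl gives a 1.3-fold lower number from compound 3 to compound 4 (0.11 log units; within the scatter) and the exchange for phenyl gives a 1.3-fold lower number from compound 2 to compound 4 (0.12 log units; within the scatter) while the exchange for methyl gives a 1.5-fold lower number from compound 1 to compound 4 (0.18 log units; within the scatter) as the largest step of the three. The earlier compounds shown here had not tested a change in where the nitrogen sits within the pyridine ring, and compound 4 shows that this change, like the replacement of either pyridine by phenyl or methyl, produces no step beyond the scatter. Nothing available here offers an explanation for why these four groups read alike.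

The compounds shown leave open whether a group of a different kind on this carbon, such as an amine, a carboxylic acid or a longer alkyl chain, would give a step beyond the scatter. They also leave open whether methyl, phenyl, pyridin-3-yl and pyridin-2-yl would still read alike on any core other than the one shared here.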